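The compounds below may be only part of what the source reports. "The series", "measured", "known", "first", "only" and "open" are said of these compounds alone.

Compound 1 `COc1ccc(-c2cn(-c3ccc(Oc4ccccc4)cc3)nn2)cc1` and compound 3 `COc1ccc(-c2cn(-c3ccc(Oc4ccccc4)cc3)nn2)cc1OC` share one core and differ in a single place, (methoxy in place of hydrogen on an aromatic carbon). In a functional assay on MDA-MB-231 cells (Homo sapiens) for cytotoxicity, read by MTT assay (a higher number here means a weaker inhibitor, a lower number a stronger inhibitor), compound 1 gives only a limit of the assay, > 100 nM. In this assay compound 3 gives 10000 nM. The step that the limit leaves unreadable from compound 1 to compound 3 has no readable size because of the limit of > 100 nM in this assay, at which 1 of the 3 values shown sits.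

Compound 2 `COc1cc(OC)cc(-c2cn(-c3ccc(OC(F)(F)F)cc3)nn2)c1` is built on a different core; the difference between the two cores is not broken down here. In this assay compound 2 gives only a limit of the assay, > 1000 nM.

Compound 4 `COc1cc(-c2cn(-c3ccc(OC(F)(F)F)cc3)nn2)cc(OC)c1OC` has not been measured in this assay. It differs from compound 2 by methoxy in place of hydrogen on an aromatic carbon. Among the compounds with values here, this is the same kind of change as the one from compound 1 to compound 3, but not the same: in compound 4 the entering methoxy sits ortho to two methoxy groups and para to a large group, whereas in compound 3 it sits ortho to a methoxy group and meta to a large group. Within the data shown here, because the only measured step of this kind reads a step that the limit leaves unreadable from compound 1 to compound 3 and gives no size, the expected step that the limit leaves unreadable from compound 2 to compound 4 is an estimate with wide uncertainty. Compound 4 is therefore expected to give about 5000 nM in this assay, within a range from 800 nM to 30000 nM.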

Compound 4, half-maximal inhibitory concentration: > 10000 nM
Compound 4 was reported as a limit (the forecaster's own chance of this, stated with the estimate: 40%); middle value at least 2.0-fold (0.30 log units) away from the limit.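

In this assay compound 2 gives only a limit of the assay, > 1000 nM. Compound 4 also gives only a limit, > 10000 nM, so no size can be read for the step between compound 2 and compound 4. The compounds shown leave open how far methoxy in place of hydrogen on an aromatic carbon shifts the value in this assay.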